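This account rests on a few compounds, and the source may have more. Where it says the series, first, only, none or still open, it means among the compounds named here.

Measured compounds:
- compound 1 `ClCc1ccc(Cn2cnc3c(Cl)ncnc32)cc1`: 8700 nM
- compound 2 `ClCc1ccccc1Cn1cnc2ncnc(Cl)c21`: 25100 nM

In a functional assay on MDA-MB-231 cells (Homo sapiens) for cytotoxicity, read by sulforhodamine B assay, with a stated time of 48 h (a lower number here means that less compound is tolerated, a higher number that more compound is tolerated), compound 1 gives 8700 nM, the lowest of the two numbers; compound 2 gives a higher number, and that gap lies beyond the scatter. Compound 3 `ClCc1ccc(Cn2cnc3c(Cl)nc(Cl)nc32)cc1` differs from compound 1 by chloro in place of hydrogen on an aromatic carbon. No such step has been measured among these compounds, so the size of the step in this assay is open; a small step toward a lower number, or none beyond the scatter, is expected. For compound 3 the estimate is 6000 nM, with a range from 2000 nM to 20000 nM. The expected step is a 1.5-fold lower number from compound 1 to compound 3 (0.16 log units; within the scatter).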

Compound 3, concentration lethal to 50% of the cells: 7240 nM
Estimate against measurement, compound 3: 1.2-fold (0.08 log units) below, within the range that was stated.
By their numbers in this assay, from the lowest: compounds 3 and 1 (each within the scatter of the next); then compound 2.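

Compound 1 and compound 2 carry only hydrogen on the aromatic carbon between two ring nitrogen atoms, so they say nothing about this position. In this assay chloro in place of hydrogen there leaves the read-out where it was, the step being a 1.2-fold lower number from compound 1 to compound 3 (0.08 log units; within the scatter) and so no real change. No measurement given here bears on this result. Going by these compounds, whether an amine or a methoxy group at this position would also leave the number unchanged stays open, as does whether chloro would do the same on the core of compound 2.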